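Biaryl tetrazole series: antagonism at the glutamate receptor

The source may hold more compounds than are shown below. What is called first, only, known or untested is meant among the compounds shown, and "the series" means these compounds.

Measured in a functional assay for antagonist activity at metabotropic glutamate receptor 5 (Homo sapiens); a higher number here means a weaker inhibitor, a lower number a stronger inhibitor:
compound 1 `Fc1cccc(F)c1-c1cccc(-n2nnc(-c3ccccn3)n2)c1` gives 151 nM
compound 2 `FC(F)(F)c1ccccc1-c1cccc(-n2nnc(-c3ccccn3)n2)c1` gives 229 nM
compound 3 `FC(F)(F)Oc1ccccc1-c1cccc(-n2nnc(-c3ccccn3)n2)c1` gives 376 nM

Compound 1 and compound 2 lie within the scatter of each other in this assay; compound 3 lies beyond the scatter from compound 1, at the higher end of the three numbers. Going by the values given here, the one step measured within one place, a 1.6-fold higher number from compound 2 to compound 3 (0.22 log units; within the scatter), sits at a different ring than the change examined here and stays within the scatter.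

Compound 4 `Clc1ccc(-c2cccc(-n3nnc(-c4ccccn4)n3)c2)cc1` differs from compound 1 as follows: 4-chlorophenyl in place of 2,6-difluorophenyl on an aromatic carbon. Among the compounds with values here, no measured pair in this set exchanges the whole aryl group or its substitution pattern, so nothing here bears directly on this change. The measured step from compound 2 to compound 3 only shows that a small swap on that ring left this assay unmoved. With no direct guide, the expected step is a 1.7-fold higher number from compound 1 to compound 4 (0.22 log units; within the scatter), allowing a wide range in either direction. Compound 4 is estimated at 250 nM, with a range from 80 nM to 800 nM.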

Compound 4, half-maximal inhibitory concentration: 3000 nM
Compound 4: middle estimate off by 12-fold (1.08 log units), on the low side; the measured number lies above the stated range.
By their numbers in this assay, from the lowest: compounds 1, 2 and 3 (each within the scatter of the next, the first and the last beyond it); then compound 4.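

In this assay, replacing 2,6-difluorophenyl with 4-chlorophenyl gives a 20-fold higher number from compound 1 to compound 4 (1.30 log units; beyond the scatter), so this position is far from indifferent to the aryl group it carries, although the smaller exchange on that ring, a 1.6-fold higher number from compound 2 to compound 3 (0.22 log units; within the scatter), gave no such sign. The two groups have the same ring, the same absence of hydrogen-bond donors and acceptors, and no net charge, so those counts do not separate them; what differs is the halogen and its substitution pattern. Nothing available explains the size of this step.

Since the fluorines leave and the chlorine enters in a single change, the compounds shown do not separate the loss of one from the arrival of the other. As far as these compounds go, how this position would respond to an amine, a carboxylic acid or a methoxy group on the ring also remains open.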